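The source may report more compounds than this note shows. Statements on the series, on what has been measured and on what is new or still open speak of the compounds shown alone.

In an ADME assay on NHDF cells (Homo sapiens) for cytotoxicity, read by MTT assay, with a stated time of 72 h (on this read-out lower numbers stand for stronger inhibition and higher numbers for weaker inhibition), compound 1 (`COc1cccc(/C=C2\CCC/C(=C\c3ccc(Br)cc3)C2=O)c1OC`) gives 21400 nM and compound 2 (`COc1ccc(/C=C2\CCC/C(=C\c3cccc(OC)c3OC)C2=O)cc1`) gives 43500 nM. Compound 3 (`COc1cccc(/C=C2\CCC/C(=C\c3cccc(Cl)c3Cl)C2=O)c1OC`) gives > 50000 nM, which is a limit of the assay and not a number. Compound 4 (`COc1cccc(/C=C2\CCC/C(=C\c3cc(Cl)cc(Cl)c3)C2=O)c1OC`) has 3,5-dichlorophenyl in place of 2,3-dichlorophenyl on a double-bonded chain carbon bound to a double-bonded ring carbon. Two measured steps change this same place. an at least 2.3-fold higher number from compound 1 to compound 3 (0.36 log units; beyond the scatter) is at least modest, while the floor of an at least 1.1-fold higher number from compound 2 to compound 3 (0.06 log units; that floor lies within the scatter) lies within the scatter. Neither exchanges one dichlorophenyl for another, so no step beyond the scatter is expected in this assay. The expected change is an at least 1.1-fold lower number from compound 3 to compound 4 (0.04 log units; that floor lies within the scatter). Compound 4 is estimated at 45000 nM, with an expected range from 20000 nM to 90000 nM.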

Compound 4, half-maximal inhibitory concentration: 21600 nM
The estimate for compound 4 lay 2.1-fold (0.32 log units) above the measured number; measured number inside the range.
By their numbers in this assay, from the lowest: compounds 1, 4 and 2 (each within the scatter of the next, the first and the last beyond it). At a limit, above all of these: compound 3.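

In this assay, within the data shown here, the exchange of one dichlorophenyl for another at this place is itself readable, an at least 2.3-fold lower number from compound 3 to compound 4 (0.36 log units; beyond the scatter), which no earlier step could show. Compound 3 carries only a limit of the assay, so this step is a floor: the limit of > 50000 nM in this assay, at which 1 of the 4 values shown sits. With 3,5-dichlorophenyl at this place, the number is not separated from those with the other two groups: a 1.0-fold higher number from compound 1 to compound 4 (0.00 log units; within the scatter), and a 2.0-fold lower number from compound 2 to compound 4 (0.30 log units; within the scatter).

The compounds shown leave open how a single chlorine would read at this place. They also leave open how a phenyl carrying an amine or a carboxylic acid would read there.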